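A few compounds are considered here, and "the series" means these few. Any claim that something is new, unique, unknown or untested is made for them only; others in the source may bear on it.

Working notes on the series. Within the data shown here, in a functional assay, read by spectrophotometry, with a stated time of 30 min (on this read-out higher numbers stand for weaker inhibition and lower numbers for stronger inhibition), compound 2 `Cc1nc2c3ccccc3ccc2c2nc3c(ccc4ccccc43)c(-c3cc(O)nc4ccccc34)c12` gives 92.1 ug/mL, and compound 1 `COc1ccc(-c2c3ccc4ccccc4c3nc3c2c(C)nc2c4ccccc4ccc32)cc1` gives 133 ug/mL; the step of a 1.4-fold lower number from compound 1 to compound 2 (0.16 log units; within the scatter) is within the scatter, so on the two numbers so far compound 2 stands level with compound 1 rather than apart from it. Compound 3 `Cc1nc2c3ccccc3ccc2c2nc3c(ccc4ccccc43)c(-c3cccnc3)c12` differs from compound 2 as follows: pyridin-3-yl in place of 2-hydroxyquinolin-4-yl on an aromatic carbon. Among the measured compounds shown here, the one step that bears on this exchange, a 1.4-fold lower number from compound 1 to compound 2 (0.16 log units; within the scatter), also swapped the group on an aromatic carbon of the shared core and stayed within the scatter, so no step beyond the scatter is expected here either. Compound 3 is therefore estimated at 100 ug/mL, with a range of 50 ug/mL to 200 ug/mL, which means an expected step of a 1.1-fold higher number from compound 2 to compound 3 (0.04 log units; within the scatter).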

Compound 3, half-maximal inhibitory concentration: 98.2 ug/mL
Beside the measured number, compound 3's estimate is 1.0-fold (0.01 log units) above it; the range from low to high includes it.
By their numbers in this assay, from the lowest: compounds 2, 3 and 1 (each within the scatter of the next).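

In this assay, the two new steps, a 1.1-fold higher number from compound 2 to compound 3 (0.03 log units; within the scatter) and a 1.4-fold lower number from compound 1 to compound 3 (0.13 log units; within the scatter), place pyridin-3-yl level with both 2-hydroxyquinolin-4-yl and 4-methoxyphenyl at this position, opposite the ring nitrogen. The exchange from compound 2 removes the six-membered aromatic ring of carbon only and the hydrogen-bond donor, yet the step stays within the scatter, so neither feature is needed to hold the number at this level among these compounds. No measurement on hand accounts for this.

On these data alone, what an amine, a carboxylic acid or a longer chain would give at this position stays open. So does whether any group here can move the number beyond the scatter.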